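Adding an Ester to the Sulfur Side Chain

The source may report more compounds than this note shows. Statements on the series, on what has been measured and on what is new or still open speak of the compounds shown alone.

Three compounds that share one core were tested in a functional assay on HT-29 cells (Homo sapiens) for cytotoxicity, read by MTT assay, with a stated time of 48 h; on this read-out lower numbers stand for stronger inhibition and higher numbers for weaker inhibition. Compound 1 `COc1cc(-c2nnc(SC)n2/N=C/c2ccccc2)cc(OC)c1OC` reached only a limit of the assay, giving > 200000 nM. Compound 2 `COc1cc(-c2nnc(SCc3ccccc3)n2/N=C/c2ccccc2)cc(OC)c1OC` also stopped at a limit, giving > 200000 nM. Going by the values given here, compound 3 `COc1ccc(/C=N/n2c(SC)nnc2-c2cc(OC)c(OC)c(OC)c2)c(OC)c1` is the only compound with an actual number, giving 144000 nM in this assay, so it stands as the sole readable point among the three. Among the compounds with values here, the one measured step that reaches it is an at least 1.3-fold lower number from compound 1 to compound 3 (0.14 log units; that floor lies within the scatter), a step whose floor is set by the limit of > 200000 nM in this assay, at which 2 of the 3 values shown sit, and which therefore cannot be sized further.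

Compound 4 `CCOC(=O)CSc1nnc(-c2cc(OC)c(OC)c(OC)c2)n1/N=C/c1ccc(OC)cc1OC` differs from compound 3 in one place: ethoxycarbonyl in place of hydrogen on a saturated chain carbon bound to a sulfur. Within the data shown here, the only measured step at this same place is a step that the two limits leave unreadable from compound 1 to compound 2, which runs between two limits and so gives no readable size in either direction. Among the measured compounds shown here, with no measured step of readable size to lean on, the change from compound 3 to compound 4 is expected to stay within the scatter, and the estimated step is a 1.0-fold higher number from compound 3 to compound 4 (0.02 log units; within the scatter). On that basis compound 4 is estimated at 150000 nM in this assay, with an expected range from 50000 nM to 400000 nM, and with a real chance that the assay again reports only a limit.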

Compound 4, half-maximal inhibitory concentration: > 200000 nM
Compound 4: only a limit was reported; the forecaster's own chance of this, stated with the estimate: 40%; middle value at least 1.3-fold (0.12 log units) from the limit.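

Going by these compounds alone, the earlier step at this place, on a saturated chain carbon bound to a sulfur, could not be read, so ethoxycarbonyl in place of hydrogen gives the first step here with a readable floor: it is an at least 1.3-fold higher number from compound 3 to compound 4 (0.14 log units; that floor lies within the scatter). Within the data shown here, the change also shows that this ester side chain, added to the one compound with an actual number, does not yield a readable number in this assay, as compound 4 reports only a limit. The true size of the step cannot be told because it stops at that limit: the limit of > 200000 nM in this assay, at which 3 of the 4 values shown sit.

The compounds shown leave open whether a carboxylic acid, an amine or a longer chain at this same place would give a readable number in this assay. Among these compounds, with only one actual number among the four compounds, they also leave open how ethoxycarbonyl would act on a compound whose value lies well clear of the limit.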